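The source may report more compounds than this note shows. Statements on the series, on what has been measured and on what is new or still open speak of the compounds shown alone.

Measured compounds in a functional assay on UACC-257 cells (Homo sapiens) for inhibition, with a stated time of 48 h; a lower number here means a stronger inhibitor of growth, a higher number a weaker inhibitor of growth:
compound 1 `NNC(=O)c1c(NC(=O)NS(=O)(=O)c2ccccc2)sc2c1CCCCC2` gives 2800 nM
compound 2 `CN1CCN(C(=O)c2c(NC(=O)NS(=O)(=O)c3ccccc3)sc3c2CCCCC3)CC1` gives > 100000 nM, a limit of the assay
compound 3 `O=C(Nc1sc2c(c1C(=O)NNc1ccc(Br)cc1)CCCCC2)NS(=O)(=O)c1ccccc1` gives > 100000 nM, a limit of the assay

Going by the values given here, compound 1 stands as the only numbered value in this assay; the other two values are limits. The unmeasured compound 4 `O=C(Nc1sc2c(c1C(=O)N1CCN(c3ccccc3)CC1)CCCCC2)NS(=O)(=O)c1ccccc1` differs from compound 1 in one place: 4-phenylpiperazin-1-yl in place of aminoamino on a carbonyl carbon. Among the compounds with values here, two measured steps bear on this change. The closest is an at least 35-fold higher number from compound 1 to compound 2 (1.55 log units; beyond the scatter), where another piperazine took the place of the same aminoamino group on the same carbonyl carbon. The second is an at least 35-fold higher number from compound 1 to compound 3 (1.55 log units; beyond the scatter), where the aminoamino group was enlarged rather than replaced. Both steps were large and in the same direction, and both ended at the limit of > 100000 nM in this assay, at which 2 of the 3 values shown sit. For compound 4 a large rise in this assay is therefore expected, most likely again reaching the limit: the expected step is a 36-fold higher number from compound 1 to compound 4 (1.55 log units; beyond the scatter). Compound 4 is estimated at 100000 nM, with a range from 20000 nM to 300000 nM.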

Compound 4, concentration for 50% growth inhibition: > 100000 nM
Compound 4: no number, only a limit; the forecaster's own chance of this, stated with the estimate: 70%; the middle value sits exactly at the limit.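

In this assay, 4-phenylpiperazin-1-yl in place of aminoamino on this carbonyl carbon gives an at least 35-fold higher number from compound 1 to compound 4 (1.55 log units; beyond the scatter), so a third replacement joins the two earlier ones in the same direction. Phenyl in place of methyl on the ring amine nitrogen, the one difference between compound 2 and compound 4, brings no numbered value back, and among the compounds shown only compound 1, with its aminoamino group, keeps a number. Compound 4 adds one more case to the limit: the limit of > 100000 nM in this assay, at which 3 of the 4 values shown sit.

The steps among compound 2, compound 3 and compound 4 cannot be read, as each of these values is a limit. From the compounds shown here alone, whether a simple amine, a methylamino group or a hydroxyl group on this carbonyl carbon would match or better compound 1 at 2800 nM stays open.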